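Swapping a Methylphenyl for a Chlorophenyl in a Soluble Series

The compounds below may be only part of what the source reports. "The series", "measured", "known", "first", "only" and "open" are said of these compounds alone.

Compound 1 `CCOC(=O)c1c(-c2ccccc2C)[nH]c2cc(OC)ccc2c1=O` has been tested in a physicochemical assay for solubility, in phosphate buffer, at pH 7.4; a lower number here means a less soluble compound, a higher number a more soluble compound. In this assay compound 1 gives > 100000 nM, which is a limit of the measurement rather than a number. Compound 2 `CCOC(=O)c1c(-c2ccccc2)[nH]c2cccc(OC)c2c1=O` gives > 100000 nM, also a limit. Compound 3 `CCOC(=O)c1c(-c2ccccc2C)[nH]c2cccc(OC)c2c1=O` gives > 100000 nM, again a limit. Compound 1 therefore stands exactly where all the other values stand: the limit of > 100000 nM in this assay, at which 3 of the 3 values shown sit. Among the compounds with values here, the only step between measured compounds that differ in one place, a step that the two limits leave unreadable from compound 2 to compound 3, cannot be read in size because both of its ends are limits.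

Compound 4 `CCOC(=O)c1c(-c2ccc(Cl)cc2)[nH]c2cc(OC)ccc2c1=O` has not yet been measured. It differs from compound 1 in one place: 4-chlorophenyl in place of 2-methylphenyl on an aromatic carbon. Within the data shown here, no measured step shows what this change does, and the one step that exists is unreadable, so the expectation can rest only on the fact that every compound so far sits at the limit. Compound 4 is expected to sit near the same limit, at an estimated 100000 nM with a range from 30000 nM to 300000 nM. The expected step of a number no higher from compound 1 to compound 4 (the limit leaves the size open) is thus estimated as none beyond the scatter.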

Compound 4, solubility: 3000 nM
For compound 4 the middle estimate is 33-fold (1.52 log units) above the measured one, outside the stated range (below it).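

In this assay, putting 4-chlorophenyl in place of 2-methylphenyl on the aromatic carbon next to the ring nitrogen gives an at least 33-fold lower number from compound 1 to compound 4 (1.52 log units; beyond the scatter). For compound 1, the value of > 100000 nM is a limit and not a number. The one earlier step cannot be read, so compound 4 gives the only sign among these compounds that the group at this place can move the read-out, with every other value still at the limit: the limit of > 100000 nM in this assay, at which 3 of the 4 values shown sit.

This single change swaps methyl for chlorine and also moves the substituent around the phenyl ring, and the compounds shown cannot separate those two differences. A 2-chlorophenyl or a 4-methylphenyl at this place would pull them apart, and a 4-chlorophenyl on the core of compound 2 would test whether the step carries over.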